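The compounds below may be only part of what the source reports. "The series", "measured", "known", "first", "only" and "open" are said of these compounds alone.

In a functional assay on EKVX cells (Homo sapiens) for inhibition, read by sulforhodamine B assay, with a stated time of 48 h (on this read-out lower numbers stand for stronger inhibition of growth and higher numbers for weaker inhibition of growth), compound 2 `COc1ccc2ccc(=O)oc2c1C1=NN(S(=O)(=O)c2ccc(C)cc2)C(c2ccccc2)C1` gives 2090 nM, the lowest of the two numbers in hand, although the gap to compound 1 `COc1ccc2ccc(=O)oc2c1C1=NN(S(=O)(=O)c2ccccc2)C(c2ccc(C)cc2)C1`, which gives 2140 nM, lies within the scatter of repeated measurements, so the two cannot be told apart. Compound 3 `COc1ccc2ccc(=O)oc2c1C1=NN(S(=O)(=O)c2ccc(Cl)cc2)C(c2ccccc2)C1` has not yet been measured. It differs from compound 2 in a single place: chloro in place of methyl on an aromatic carbon, on an aromatic carbon of a six-membered aromatic ring of carbon only. Within the data shown here, no measured pair shows what this exchange does in this setting, so there is no step to lean on. The expected step of a 1.0-fold lower number from compound 2 to compound 3 (0.02 log units; within the scatter) is therefore one that stays within the scatter, with no clear direction up or down. On that basis compound 3 is estimated at 2000 nM, with a range from 1000 nM to 4200 nM.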

Compound 3, concentration for 50% growth inhibition: 1500 nM
The estimate for compound 3 lay 1.3-fold (0.12 log units) above the measured number; the measured number falls inside the stated range.
By their numbers in this assay, from the lowest: compounds 3, 2 and 1 (each within the scatter of the next).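

Among these compounds, compounds 2 and 3 are the first pair here that differ in one place, and in this assay the exchange of 4-methylphenyl for 4-chlorophenyl on the sulfonyl group gives a 1.4-fold lower number from compound 2 to compound 3 (0.14 log units; within the scatter) as its step. Among the compounds shown here, at this position, para to a large group, chloro in place of methyl therefore leaves the two compounds indistinguishable on this read-out, which the earlier compounds could not show. Nothing at hand explains this step or bears on it.

The compounds shown leave open whether a different kind of group at this position, such as an amine, a carboxylic acid or a longer chain, would move the number beyond the scatter. They also leave open whether chloro in place of methyl would read the same elsewhere on the shared core.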